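A few compounds are considered here, and "the series" means these few. Any claim that something is new, unique, unknown or untested is made for them only; others in the source may bear on it.

Measured so far:
Compound 1, `CSc1ccc(-c2nc3c(Sc4ccc(F)cc4)ncnc3n2C)cc1`: 7%
Compound 2, `Cn1c(-c2ccc([S+](C)[O-])cc2)nc2c(Sc3ccccc3)ncnc21`: 8%

Of the compounds shown here, two have been tested in an assay on isolated protein for inhibition of Ca2+/calmodulin-dependent protein kinase II (CaM kinase II) (Rattus norvegicus), tested at 30 uM; on this read-out lower numbers stand for less inhibition and higher numbers for more inhibition at the one concentration tested (going by the name of the read-out). Compound 1 gives 7%, and compound 2 gives 8%. The two numbers lie within the usual scatter of this kind of measurement, so neither compound can be said to inhibit more than the other; both show little inhibition at the concentration tested. Compound 2 is the starting point for the next step.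

Compound 3 is `Cn1c(-c2ccc([S+](C)[O-])cc2)nc2c(Sc3ccc(F)cc3)ncnc21`. It differs from compound 2 in one place: fluoro in place of hydrogen on an aromatic carbon. The phenylsulfanyl group of compound 2 becomes a (4-fluorophenyl)sulfanyl group in compound 3. Compound 1 already carries a (4-fluorophenyl)sulfanyl group, though on a partner bearing methylsulfanyl rather than methylsulfinyl, and its number is within the scatter of that of compound 2. Going by the values given here, no measured pair shows this change on its own. Given the low numbers of compound 1 and compound 2, the step from compound 2 to compound 3 is expected to stay within the scatter, no change at the digits printed from compound 2 to compound 3 (within the scatter). Compound 3 is therefore expected to give about 8% in this assay, between 0% and 18%.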

Compound 3, a percentage reported as inhibition, at one concentration (the size of the read-out at that concentration, not a potency): 12%
Compound 3: the middle estimate sits 4 percentage points below what was measured; the measured number falls inside the stated range.
By their numbers in this assay, from the lowest: compounds 1, 2 and 3 (each within the scatter of the next).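

In this assay, fluoro in place of hydrogen on an aromatic carbon, para to a large group, gives a number 4 percentage points higher from compound 2 to compound 3 (within the scatter). Going by these compounds alone, this is the first direct reading of that single change, and it shows that the (4-fluorophenyl)sulfanyl and phenylsulfanyl versions cannot be told apart here, while the methylsulfinyl group in place of the methylsulfanyl group on the other aromatic ring gives a number 5 percentage points higher from compound 1 to compound 3 (within the scatter), so neither swap moves the number beyond what repeated measurements would scatter by. Nothing available on these compounds offers an explanation for this result.

All three compounds show only low inhibition at the one concentration tested, so these steps say little about how the two positions would behave in a more strongly inhibiting compound. On these data alone, whether a different group at either position, such as a methoxy group or an amine on the sulfanyl-linked ring, or a carboxylic acid in place of the methylsulfinyl group, would give a step beyond the scatter remains open.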